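Trimethoxyphenyl at the ring carbon: an expected outcome

The source may hold more compounds than are shown below. What is called first, only, known or untested is meant among the compounds shown, and "the series" means these compounds.

Compound 1 `COc1ccc(-c2cn(-c3cccc(C(=O)/C=C/c4cc(OC)c(OC)c(OC)c4)c3)c(=O)[nH]2)cc1` is one of three compounds tested in a functional assay on RXF 393 cells (Homo sapiens) for inhibition (a higher number here means a weaker inhibitor of growth, a lower number a stronger inhibitor of growth), where compound 1 gives 1920 nM. Among those three numbers it holds the second highest; compound 3 `O=C(/C=C/c1cccc(O)c1)c1cccc(-n2cc(-c3ccccc3)[nH]c2=O)c1` gives 1890 nM, which lies within the scatter of compound 1, while compound 2 `COc1ccc(-c2cn(-c3cccc(C(=O)/C=C/c4ccc(O)c(OC)c4)c3)c(=O)[nH]2)cc1` gives 5850 nM, a step of a 3.0-fold higher number from compound 1 to compound 2 (0.48 log units; beyond the scatter).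

Compound 4 `COc1cc(/C=C/C(=O)c2cccc(-n3cc(-c4cc(OC)c(OC)c(OC)c4)[nH]c3=O)c2)cc(OC)c1OC` differs from compound 1 in one place: 3,4,5-trimethoxyphenyl in place of 4-methoxyphenyl on an aromatic carbon. Among the measured compounds shown here, the only measured step, from compound 1 to compound 2, concerns the group on the double-bonded chain carbon, not the aromatic carbon of the five-membered ring, so it does not bear directly on this change. Compounds 1 and 3 differ in two places at once and allow no isolated reading, and their values show similar numbers. For the measured compounds named here, with no step that speaks to the ring-carbon substituent, compound 4 is expected to stay close to compound 1, a step of a 1.0-fold higher number from compound 1 to compound 4 (0.02 log units; within the scatter). For compound 4 the estimated value in this assay is 2000 nM, within a range of 800 nM to 5000 nM.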

Compound 4, concentration for 50% growth inhibition: 1620 nM
The estimate for compound 4 lay 1.2-fold (0.09 log units) above the measured number; the range from low to high includes it.
By their numbers in this assay, from the lowest: compounds 4, 3 and 1 (each within the scatter of the next); then compound 2.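

Among the compounds shown here, this is the first measured step at the aromatic carbon of the five-membered ring: 3,4,5-trimethoxyphenyl in place of 4-methoxyphenyl gives a 1.2-fold lower number from compound 1 to compound 4 (0.07 log units; within the scatter) in this assay, so compound 1 and compound 4 cannot be told apart. At this position, then, the heavier substitution pattern on the phenyl ring leaves the growth inhibition where it was, whereas the earlier step at the other end of the molecule, a 3.0-fold higher number from compound 1 to compound 2 (0.48 log units; beyond the scatter), lay beyond the scatter. Nothing shown explains why the number holds at the ring carbon.

Still open, going by these compounds, is whether a phenyl ring carrying an amine or a carboxylic acid at this position would behave the same way. On these data alone, it is also open whether 3,4,5-trimethoxyphenyl here would leave the number undisturbed alongside the 4-hydroxy-3-methoxyphenyl chain end of compound 2.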